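A few compounds are considered here, and "the series" means these few. Any claim that something is new, unique, unknown or untested is made for them only; others in the source may bear on it.

Measured so far in a functional assay on U-937 cells (Homo sapiens) for cytotoxicity, read by MTT assay, with a stated time of 24 h; on this read-out higher numbers stand for weaker inhibition and lower numbers for stronger inhibition:
Compound 1, `Nc1nn(Cc2cn(-c3ccc([N+](=O)[O-])cc3)nn2)c2nc(-c3ccccc3)cc(C(F)(F)F)c12`, gives 98.8 ug/mL.
Compound 2, `Cc1ccc(NC(=O)Cn2cc(Cn3nc(N)c4c(C(F)(F)F)cc(-c5ccccc5)nc43)nn2)cc1`, gives 65.3 ug/mL.

Compound 2 stands alongside compound 1 rather than apart from it: the step of a 1.5-fold lower number from compound 1 to compound 2 (0.18 log units; within the scatter), so on these numbers the two compounds cannot be told apart. Compound 3, `Nc1nn(Cc2cn(CC(=O)Nc3ccc(F)cc3Br)nn2)c2nc(-c3ccccc3)cc(C(F)(F)F)c12`, differs from compound 2 by 2-bromo-4-fluorophenyl in place of 4-methylphenyl on an amide-type nitrogen. For the measured compounds named here, the one step measured so far changed a different part of the molecule, the group on the aromatic nitrogen, and stayed within the scatter; it says nothing direct about exchanging one ring for another on the amide nitrogen. Going by the values given here, with no measured step that bears on this change, no movement beyond the scatter is expected in this assay. Compound 3 is therefore estimated at 60 ug/mL, with a range from 25 ug/mL to 150 ug/mL. The expected step is a 1.1-fold lower number from compound 2 to compound 3 (0.04 log units; within the scatter), a change too small to count as real.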

Compound 3, half-maximal inhibitory concentration: 98.3 ug/mL
Compound 3: the middle estimate sits 1.6-fold (0.21 log units) below what was measured; measured number inside the range.
By their numbers in this assay, from the lowest: compounds 2, 3 and 1 (each within the scatter of the next).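

In this assay, for the compounds shown here, putting 2-bromo-4-fluorophenyl in place of 4-methylphenyl on the amide-type nitrogen gives the first measured step at this position (a 1.5-fold higher number from compound 2 to compound 3 (0.18 log units; within the scatter)), and it leaves compound 2 and compound 3 indistinguishable. Putting ((2-bromo-4-fluorophenyl)carbamoyl)methyl in place of 4-nitrophenyl on the aromatic nitrogen (a 1.0-fold lower number from compound 1 to compound 3 (0.00 log units; within the scatter)) likewise leaves compound 1 and compound 3 indistinguishable, so two quite different groups on that aromatic nitrogen give numbers that cannot be separated. No independent measurement is available to explain these results.

Still open, on these data alone, is whether a group without an aromatic ring on the amide-type nitrogen, such as a longer carbon chain or a carboxylic acid, would give a step beyond the scatter. Also open, as far as these compounds go, is what a ring carrying only bromine or only fluorine would give.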